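Swapping a chlorophenyl for a trifluoromethylphenyl on the triazole

A few compounds are considered here, and "the series" means these few. Any claim that something is new, unique, unknown or untested is made for them only; others in the source may bear on it.

Compound 3 `N#CC1=C(N)Oc2c(N)cc3nc4ccccc4nc3c2C12C(=O)N(Cc1cnnn1-c1ccc(Cl)cc1)c1ccccc12` is one of three measured members of this shared core. In a functional assay on HepG2 cells (Homo sapiens) for antiproliferative activity, read by MTT assay, with a stated time of 48 h (a lower number here means a stronger inhibitor, a higher number a weaker inhibitor), compound 3 gives > 50000 nM, which is a limit of the assay rather than a number. Compound 1 `Cc1cccc(-n2nncc2CN2C(=O)C3(C(C#N)=C(N)Oc4c(N)cc5nc6ccccc6nc5c43)c3ccccc32)c1` gives > 50000 nM in this assay, again a limit. Compound 2 `CCc1ccccc1-n1nncc1CN1C(=O)C2(C(C#N)=C(N)Oc3c(N)cc4nc5ccccc5nc4c32)c2ccccc21`, by contrast, gives a number, 17900 nM in this assay. The step of an at least 2.7-fold lower number from compound 1 to compound 2 (0.44 log units; beyond the scatter) and the step of an at least 2.7-fold higher number from compound 2 to compound 3 (0.44 log units; beyond the scatter) are both readable, while the step that the two limits leave unreadable from compound 1 to compound 3 is not. Compound 4 `N#CC1=C(N)Oc2c(N)cc3nc4ccccc4nc3c2C12C(=O)N(Cc1cnnn1-c1cccc(C(F)(F)F)c1)c1ccccc12` differs from compound 3 by 3-(trifluoromethyl)phenyl in place of 4-chlorophenyl on an aromatic nitrogen. For the measured compounds named here, no measured step exchanges one aryl group for another of this kind, so the expectation rests only on the position of compound 3 and on (the limit of > 50000 nM in this assay, at which 2 of the 3 values shown sit). For compound 4 the step of a number no higher from compound 3 to compound 4 (the limit leaves the size open) is therefore expected to stay within the scatter. The estimate for compound 4 in this assay is 50000 nM, with a range from 15000 nM to 100000 nM, and another limit is considered likely.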

Compound 4, half-maximal inhibitory concentration: 15800 nM
Compound 4: middle estimate off by 3.2-fold (0.50 log units), on the high side; the measured number falls inside the stated range.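

Changing the aryl group on this aromatic nitrogen can lift a compound off the assay limit: in this assay, 3-(trifluoromethyl)phenyl in place of 4-chlorophenyl gives an at least 3.1-fold lower number from compound 3 to compound 4 (0.50 log units; beyond the scatter). The single substituent on the phenyl ring also counts, since trifluoromethyl in place of methyl on an aromatic carbon gives an at least 3.1-fold lower number from compound 1 to compound 4 (0.50 log units; beyond the scatter). A second aryl group now reads alongside the first, with 3-(trifluoromethyl)phenyl in place of 2-ethylphenyl giving a 1.1-fold lower number from compound 2 to compound 4 (0.05 log units; within the scatter), so two different groups at this place give readable numbers that lie within the scatter of each other.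

Readable numbers remain few in this small set: the limit of > 50000 nM in this assay, at which 2 of the 4 values shown sit. Whether an amine, a carboxylic acid or a longer chain on this phenyl ring would move the number any further stays open.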